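Compound 3 and the ring methyl in the cytotoxicity series

The source may report more compounds than this note shows. Statements on the series, on what has been measured and on what is new or still open speak of the compounds shown alone.

Measured so far in a functional assay on MDCK cells (Canis lupus familiaris) for inhibition; on this read-out lower numbers stand for higher toxicity in this test and higher numbers for lower toxicity in this test
compound 1 `CCCOc1nc(CC2(C)CCCO2)cc(=O)n1C` gives 860000 nM
compound 2 `CCCCOc1nc(CC2(C)CCCO2)cc(=O)n1C` gives 1080000 nM
compound 3 `CCCOc1nc(CC2CCCO2)cc(=O)n1C` has no value yet

Among the compounds with values here, compound 1 at 860000 nM has a single neighbour on the scale, and the one measured step is a 1.3-fold higher number from compound 1 to compound 2 (0.10 log units; within the scatter) so the two values carry no order. Compound 3 differs from compound 1 as hydrogen in place of methyl on a saturated ring carbon and in words this is hydrogen in place of methyl on a saturated ring carbon. Within the data shown here, no measured step touches that ring carbon. Among the measured compounds shown here, the one step at hand, a 1.3-fold higher number from compound 1 to compound 2 (0.10 log units; within the scatter) on the chain, is a methyl in place of hydrogen on a saturated chain carbon, so it bears on this change only loosely. It still offers no ground for expecting movement in this assay beyond the scatter. The expected size is a 1.0-fold lower number from compound 1 to compound 3 (0.01 log units; within the scatter) and no real shift in either direction is anticipated. Compound 3 is estimated at 850000 nM with an expected range from 400000 nM to 1600000 nM in this read-out.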

Compound 3, half-maximal cytotoxic concentration: 1020000 nM
Estimate against measurement, compound 3: 1.2-fold (0.08 log units) below; measured number inside the range.
By their numbers in this assay, from the lowest: compounds 1, 3 and 2 (each within the scatter of the next).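

Going from 2-methyloxolan-2-yl to oxolan-2-yl gives a 1.2-fold higher number from compound 1 to compound 3 (0.07 log units; within the scatter) in this assay, the first reading at this saturated ring carbon next to the ring oxygen. On these numbers, the methyl at this position is not needed for the value seen in compound 1, and hydrogen in its place gives no resolved change, so this ring position joins the chain as a second place where a single change stays within the scatter. No supporting data bear on why the read-out holds at this position.

The compounds shown leave open whether a larger group on this ring carbon, such as a phenyl or an amine, would give a step beyond the scatter. They also leave open whether hydrogen at this position would read the same on the chain of compound 2.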